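Fluoro in place of methoxy: three measured, one estimated

A few compounds are considered here, and "the series" means these few. Any claim that something is new, unique, unknown or untested is made for them only; others in the source may bear on it.

Measured compounds:
Compound 1 `COc1ccc2[nH]cc(/C=C(\C#N)C(=O)c3c[nH]c4cc(F)ccc34)c2c1`: in a functional assay on PC-3 cells (Homo sapiens) for cytotoxicity, read by WST assay, with a stated time of 48 h (a lower number here means a stronger inhibitor, a higher number a weaker inhibitor), compound 1 gives > 50000 nM, which is a limit of the assay rather than a number.
Compound 2 `COc1ccc2c(C(=O)/C(C#N)=C/c3c[nH]c4ccc(OC)cc34)c[nH]c2c1`: in this assay compound 2 gives 37100 nM.
Compound 3 `COc1ccc(Cn2cc(/C=C(\C#N)C(=O)c3c[nH]c4cc(OC)ccc34)c3ccccc32)cc1`: in this assay compound 3 gives > 50000 nM, again a limit of the assay.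

The difference between the core of compound 2 and the core of compound 3 is not broken down here. Compound 4 `COc1ccc(Cn2cc(/C=C(\C#N)C(=O)c3c[nH]c4cc(F)ccc34)c3ccccc32)cc1` is not yet measured. It is reached from compound 3 by fluoro in place of methoxy on an aromatic carbon, the same change as from compound 2 to compound 1, (fluoro in place of methoxy on an aromatic carbon), for which the measured step is an at least 1.3-fold higher number from compound 2 to compound 1 (0.12 log units; that floor lies within the scatter); that floor lies within the scatter. Two of the three values sit at the limit of > 50000 nM in this assay, at which 2 of the 3 values shown sit, compound 3 among them, so the step to compound 4 is expected to be small and to stay at the limit, a step that the limit leaves unreadable from compound 3 to compound 4. For compound 4 the expected value is 80000 nM, with a range from 40000 nM to 200000 nM.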

Compound 4, half-maximal inhibitory concentration: > 50000 nM
Compound 4 gave a limit, no number (the forecaster's own chance of this, stated with the estimate: 85%); the middle value lies beyond the limit too.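

No step can be read from compound 3 to compound 4 in this assay, because both compounds give a limit of the assay rather than a number: the limit of > 50000 nM in this assay, at which 3 of the 4 values shown sit.

The compounds shown leave open how far fluoro in place of methoxy shifts the value on the core of compound 3, and whether any such shift matches that on the core of compound 2.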